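Shortening the side-chain amine of compound 3

The source may hold more compounds than are shown below. What is called first, only, known or untested is meant among the compounds shown, and "the series" means these compounds.

Measured in a functional assay on HCT-116 cells (Homo sapiens) for antiproliferative activity, read by sulforhodamine B assay, with a stated time of 72 h; on this read-out lower numbers stand for stronger inhibition and higher numbers for weaker inhibition:
- compound 1 `Cn1ncc(Cl)c1-c1cc(C(=O)N[C@H]2CNCC[C@@H]2c2ccc(C(F)(F)F)cc2)oc1Cl`: 1050 nM
- compound 2 `Cn1ncc(Cl)c1-c1cc(C(=O)N[C@@H]2CN[C@H](CCO)C[C@H]2c2ccc(F)c(F)c2)oc1Cl`: 360 nM
- compound 3 `Cn1ncc(Cl)c1-c1cc(C(=O)N[C@@H]2CN[C@H](CCN3CCC(O)CC3)C[C@H]2c2ccc(Cl)c(Cl)c2)oc1Cl`: 13700 nM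

Compound 3 stands at the highest of the three numbers in this assay; compound 1 sits at a lower number and compound 2 lower still, both gaps beyond the scatter. Compound 4 `CN(C)CC[C@@H]1C[C@@H](c2ccc(Cl)c(Cl)c2)[C@H](NC(=O)c2cc(-c3c(Cl)cnn3C)c(Cl)o2)CN1` is not yet measured. It differs from compound 3 in one place: dimethylamino in place of 4-hydroxypiperidin-1-yl on a saturated chain carbon, two bonds along the chain from a saturated ring carbon. For the measured compounds named here, no measured pair isolates this change, so nothing shows directly how it reads in this assay. The expectation rests only on compound 3 lying well above the other two. Compound 4 is therefore expected to move back toward the lower numbers, a step of a 3.9-fold lower number from compound 3 to compound 4 (0.59 log units; beyond the scatter), to an estimated 3500 nM within a range of 900 nM to 14000 nM.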

Compound 4, half-maximal inhibitory concentration: 1710 nM
Estimate against measurement, compound 4: 2.0-fold (0.31 log units) above, and the stated range covers the measured number.
By their numbers in this assay, from the lowest: compound 2; then compounds 1 and 4 (each within the scatter of the next); then compound 3.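

Dimethylamino in place of 4-hydroxypiperidin-1-yl gives an 8.0-fold lower number from compound 3 to compound 4 (0.90 log units; beyond the scatter) in this assay, the first direct reading of any change on this chain. In this pair, the 2-(4-hydroxypiperidin-1-yl)ethyl group is not needed for the lower number, and 2-(dimethylamino)ethyl, which has no ring, carries it instead. Nothing at hand explains the step.

This single pair cannot separate the loss of the ring from the loss of its hydroxyl. Piperidin-1-yl without the hydroxyl, morpholin-4-yl or a primary amine on the same chain would begin to tell these apart.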